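Series notes: stereoisomer of the triazole diol analogue

The source may hold more compounds than are shown below. What is called first, only, known or untested is meant among the compounds shown, and "the series" means these compounds.

Three analogues of the shared core have been measured in a functional assay on A-375 cells (Homo sapiens) for cytotoxicity, read by MTT assay, with a stated time of 72 h; a lower number here means a stronger inhibitor, a higher number a weaker inhibitor. Compound 1 `O=C1c2c[n+]([O-])c3ccccc3c2C(=O)c2c1c1ccccc1n2Cc1cn(C[C@@H](O)CO)nn1` gives 140 nM, compound 2 `O=C1c2c[n+]([O-])c3ccccc3c2C(=O)c2c1c1ccccc1n2CCCCN1CCCCC1` gives 190 nM, and compound 3 `CC1(C)OC[C@H](Cn2cc(Cn3c4c(c5ccccc53)C(=O)c3c[n+]([O-])c5ccccc5c3C4=O)nn2)O1` gives 180 nM. Compound 2 has the highest of the three numbers, but its gaps to compound 3 and to compound 1 both sit within the scatter, so the three are read as indistinguishable. The step of a 1.4-fold higher number from compound 1 to compound 2 (0.13 log units; within the scatter) and the step of a 1.3-fold higher number from compound 1 to compound 3 (0.11 log units; within the scatter) both show that exchanging the group on the saturated chain carbon bound to the aromatic nitrogen has left this assay essentially flat across the set.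

Compound 4 `O=C1c2c[n+]([O-])c3ccccc3c2C(=O)c2c1c1ccccc1n2Cc1cn(C[C@H](O)CO)nn1` is now to be measured. Relative to compound 2 the change is 1-(2,3-dihydroxypropyl)-1H-1,2,3-triazol-4-yl in place of 3-(piperidin-1-yl)propyl on a saturated chain carbon bound to an aromatic nitrogen. The entering group is the same one carried by compound 1, differing only in the configuration at its single defined stereocentre. The step that bears directly is a 1.4-fold higher number from compound 1 to compound 2 (0.13 log units; within the scatter), reversed here; since it lay within the scatter, and no pair in this set has yet shown a stereocentre to matter, no step beyond the scatter is expected in this assay from compound 2 to compound 4. Compound 4 is therefore estimated at 150 nM, with a range of 70 nM to 320 nM, which means an expected step of a 1.3-fold lower number from compound 2 to compound 4 (0.10 log units; within the scatter).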

Compound 4, half-maximal inhibitory concentration: 350 nM
Estimate against measurement, compound 4: 2.3-fold (0.37 log units) below, and the stated range ends below it.
By their numbers in this assay, from the lowest: compounds 1, 3, 2 and 4 (each within the scatter of the next, the first and the last beyond it).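

In this assay, for the compounds shown here, the configuration drawn at the stereocentre on the saturated chain carbon gives the first step to pass beyond the scatter, a modest one (a 2.5-fold higher number from compound 1 to compound 4 (0.40 log units; beyond the scatter)). This step can be assigned to that stereocentre alone because of one fact: the fact that compounds 1 and 4 differ only in the configuration as drawn.

The exchanges that reach compound 4 stay within the scatter (a 1.8-fold higher number from compound 2 to compound 4 (0.27 log units; within the scatter); a 1.9-fold higher number from compound 3 to compound 4 (0.29 log units; within the scatter)), so at this position the configuration of the diol separates two compounds where no exchange of group yet has.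

Open is whether configuration counts equally with 2,2-dimethyl-1,3-dioxolan-4-yl, shown here in one form only. Also open, going by these compounds, is whether a carboxylic acid or a primary amine in place of the diol would follow compound 1 or compound 4.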